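The compounds below may be only part of what the source reports. "The series", "measured", "known", "first", "only" and "open" are said of these compounds alone.

Of the compounds shown here, three have been measured in an assay (strain Wistar) for inhibition of Hormone-sensitive lipase (Rattus norvegicus), read by spectrophotometry; a higher number here means a weaker inhibitor, a lower number a stronger inhibitor. Compound 1 `Cc1c(Sc2ccc(Cl)cc2)c(=O)on1C(=O)N1CCCCC1` gives 6 nM there, and compound 2 `Cc1c(S(=O)(=O)c2ccc(Cl)cc2)c(=O)on1C(=O)N1CCCCC1`, in which that sulfur link has been oxidised, gives 35 nM in this assay. Compound 3 `Cc1c(C(C)C)c(=O)on1C(=O)N1CCCCC1` carries an isopropyl group on the shared core in place of the arylthio group and gives 2 nM in this assay; this is the lowest of the three numbers, the gap to compound 1 and the larger gap to compound 2 both lying beyond the scatter, so compound 3 is the most potent of the three.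

Compound 4 `Cc1c(C2CCCC2)c(=O)on1C(=O)N1CCCCC1` has not yet been measured. It differs from compound 3 in one place: cyclopentyl in place of isopropyl on an aromatic carbon. Among the measured compounds shown here, no measured pair in this set shows a change of this kind, so no step of this size is on record for comparison. The branched group that leaves and the ring that enters are both made of carbon only, and the expectation is a step in this assay that is small, if any, and of uncertain direction, possibly none beyond the scatter.

Compound 4 is therefore estimated at 3 nM in this assay, within a range of 1 nM to 10 nM, which means an expected step of a 1.5-fold higher number from compound 3 to compound 4 (0.18 log units; within the scatter).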

Compound 4, half-maximal inhibitory concentration: 6 nM
For compound 4 the middle estimate is 2.0-fold (0.30 log units) below the measured one; the range from low to high includes it.
By their numbers in this assay, from the lowest: compound 3; then compounds 1 and 4 (each within the scatter of the next); then compound 2.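

Moving from isopropyl to cyclopentyl on this aromatic carbon is not a silent change in this assay: it gives a 3.0-fold higher number from compound 3 to compound 4 (0.48 log units; beyond the scatter), a modest step, but the first on record here between two groups made of carbon only, with no hydrogen-bond donor, acceptor or charge entering or leaving. Compound 4 gives 6 nM and compound 1 gives 6 nM, so the cyclopentyl ring and the arylthio group of compound 1 stand within the scatter of each other at this position, while compound 3, with its isopropyl group, remains the most potent of the four. Nothing available bears on the reason for this step.

With only isopropyl and cyclopentyl as the carbon-only groups shown, it stays open whether the number follows the size of the group or the presence of a ring, a question that a cyclopropyl ring, a tert-butyl group or a cyclohexyl ring at this position would address. Also open, on these data alone, is how this position would respond to a group carrying an amine or a hydroxyl, and whether the step would hold with an ethyl group in place of the methyl group.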